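Formyl in place of hydroxymethyl on the saturated core

This account rests on a few compounds, and the source may have more. Where it says the series, first, only, none or still open, it means among the compounds named here.

For the measured compounds named here, compound 1 `C=C1C(=O)[C@H]2C[C@]1(O)CC1=C2[C@]2(C)CCCC(C)(C)[C@H]2CC1` is the one member of this set with a readable number in a functional assay on SH-SY5Y cells (Homo sapiens) for cytotoxicity, read by MTT assay, with a stated time of 24 h; on this read-out lower numbers stand for stronger inhibition and higher numbers for weaker inhibition: compound 1 gives 1600 nM. Compound 2 `C[C@@H]1C(=O)[C@H]2C[C@]1(O)CC1=C2[C@]2(C)CCC[C@](C)(CO)[C@H]2CC1` returns only a limit in this assay, > 50000 nM. Compound 3 `C[C@@H]1C(=O)[C@H]2C[C@]1(O)CC1=C2[C@]2(C)CCCC(C)(C)[C@H]2CC1` also returns only a limit in this assay, > 50000 nM. Going by the values given here, the one measured step, a step that the two limits leave unreadable from compound 2 to compound 3, hydrogen in place of hydroxy on a saturated chain carbon bound to a saturated ring carbon, cannot be sized because the limit of > 50000 nM in this assay, at which 2 of the 3 values shown sit, caps both of its ends. Compound 2 therefore stands at the limit, as does compound 3, and only compound 1 gives a figure.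

Compound 4 `C[C@@H]1C(=O)[C@H]2C[C@]1(O)CC1=C2[C@]2(C)CCC[C@](C)(C=O)[C@H]2CC1` differs from compound 2 by formyl in place of hydroxymethyl on a saturated ring carbon. Among the compounds with values here, no measured step covers this change; the step from compound 2 to compound 3 is the only one at hand and it is unreadable. Compound 4 keeps the saturated methyl that compounds 2 and 3 share, both of which sit at the limit, whereas compound 1 carries the exocyclic methylene instead. Compound 4 is therefore expected to remain weak, with a step of a number no higher from compound 2 to compound 4 (the limit leaves the size open) expected to show no readable gain. The estimate for compound 4 in this assay is 50000 nM, within 10000 nM to 150000 nM.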

Compound 4, half-maximal inhibitory concentration: > 50000 nM
Compound 4 was reported as a limit; the forecaster's own chance of this, stated with the estimate: 70%; the middle value lies on the limit itself.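

No step from compound 2 to compound 4 can be read in this assay, because one limit caps both ends: the limit of > 50000 nM in this assay, at which 3 of the 4 values shown sit.

The compounds shown leave open how formyl and hydroxymethyl on the saturated ring carbon compare on a shared core that gives a readable value in this assay rather than a limit.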